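This account rests on a few compounds, and the source may have more. Where it says the series, first, only, none or still open, it means among the compounds named here.

Working notes on the series. In an ADME assay on HEp-2 cells (Homo sapiens) for cytotoxicity (a higher number here means that more compound is tolerated, a lower number that less compound is tolerated), compound 3 `CC(C)CCn1c(Cn2c(=O)n(C(C)C)c3ccccc32)nc2cc(Br)ccc21` gives 18100 nM and compound 1 `CC(C)CCn1c(Cn2c(=O)n(C(C)C)c3ccccc32)nc2cc(CNC3CC3)ccc21` gives 17200 nM, while compound 2 `CC(C)CCn1c(Cn2c(=O)n(C(C)C)c3ccccc32)nc2cc(CO)ccc21` gives 31600 nM on the same read-out. All three numbers lie within the scatter of one another, so compound 3 holds no distinct place among them.

The next change leads to compound 4 `COC(=O)c1ccc2c(c1)nc(Cn1c(=O)n(C(C)C)c3ccccc31)n2CCC(C)C` and is methoxycarbonyl in place of bromo on an aromatic carbon. For the measured compounds named here, no measured compound carries methoxycarbonyl, so the evidence is indirect. The closest steps are those that exchange the group on this same aromatic carbon: a 1.1-fold higher number from compound 1 to compound 3 (0.02 log units; within the scatter) and a 1.7-fold lower number from compound 2 to compound 3 (0.24 log units; within the scatter) as well as a 1.8-fold higher number from compound 1 to compound 2 (0.26 log units; within the scatter) for a change within that group. Each of these steps stays within the scatter, and that holds for these three compounds only. No step beyond the scatter is therefore expected in this assay for the new group, although a group not yet tested here leaves that expectation open. The expected change is small, an estimated 1.2-fold higher number from compound 3 to compound 4 (0.08 log units; within the scatter) and so within the scatter. For compound 4 an estimated 22000 nM is expected, within a range from 10000 nM to 45000 nM for repeat measurements.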

Compound 4, half-maximal cytotoxic concentration: 33700 nM
Beside the measured number, compound 4's estimate is 1.5-fold (0.19 log units) below it, within the range that was stated.
By their numbers in this assay, from the lowest: compounds 1, 3, 2 and 4 (each within the scatter of the next).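

In this assay the exchange of bromo for methoxycarbonyl on this aromatic carbon brings in four heavy atoms for one, along with a double bond outside the aromatic rings and two hydrogen-bond acceptors, yet it gives a 1.9-fold higher number from compound 3 to compound 4 (0.27 log units; within the scatter) as its step. Set against the other two groups at the same carbon, methoxycarbonyl gives a 1.1-fold higher number from compound 2 to compound 4 (0.03 log units; within the scatter) in place of hydroxymethyl and a 2.0-fold higher number from compound 1 to compound 4 (0.29 log units; within the scatter) in place of (cyclopropylamino)methyl, so all three new steps remain within the scatter. Methoxycarbonyl therefore joins bromo, hydroxymethyl and (cyclopropylamino)methyl as a fourth group at this carbon that does not separate from the others in this read-out, and no measurement at hand offers an explanation for that flat result.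

Going by these compounds, whether a carboxylic acid, a primary amide or a longer chain on this aromatic carbon would produce a step beyond the scatter remains open, since the four compounds cover only these groups. All four also share the rest of the structure, so they say nothing about how changes elsewhere on the core would read in this assay or whether this flatness would persist on a different core.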